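Extending the aryl methyl to ethyl in a thioether diacid series

This account rests on a few compounds, and the source may have more. Where it says the series, first, only, none or still open, it means among the compounds named here.

Measured compounds:
- compound 1, `O=C(O)CSC(CC(=O)c1ccccc1)C(=O)O`: 15000 nM
- compound 2, `Cc1ccc(C(=O)CC(SCC(=O)O)C(=O)O)c(C)c1`: 3830 nM
- compound 3, `Cc1ccc(C(=O)CC(SCC(=O)O)C(=O)O)cc1`: 17300 nM

All three share a core in which a thioether diacid chain carries a ketone linked to an aromatic ring. In a functional assay on HeLa cells (Homo sapiens) (a higher number here means a weaker inhibitor, a lower number a stronger inhibitor), compound 3 gives the highest number of the three. Its nearest neighbour is compound 1, and the step of a 1.2-fold higher number from compound 1 to compound 3 (0.06 log units; within the scatter) falls within the scatter. The step of a 4.5-fold higher number from compound 2 to compound 3 (0.65 log units; beyond the scatter) is modest but real, so compound 2 stands apart from compound 3.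

Compound 4, `CCc1ccc(C(=O)CC(SCC(=O)O)C(=O)O)cc1`, has not been measured. It differs from compound 3 by methyl in place of hydrogen on a saturated chain carbon bound to an aromatic carbon, which is the same thing as turning the methyl of compound 3 into an ethyl. Among the measured compounds shown here, no measured step makes exactly this change. The closest evidence is the pair of compound 1 and compound 3, where adding a methyl directly on the ring left the number within the scatter, and the pair of compound 2 and compound 3, where a second ring methyl mattered. Growing the existing methyl one carbon further out is therefore expected to give little change, and the step of a 1.2-fold lower number from compound 3 to compound 4 (0.06 log units; within the scatter) is expected to stay near the scatter. Compound 4 is estimated at 15000 nM, with a range from 6000 nM to 40000 nM.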

Compound 4, half-maximal inhibitory concentration: 4790 nM
The estimate for compound 4 lay 3.1-fold (0.50 log units) above the measured number, and the stated range ends above it.
By their numbers in this assay, from the lowest: compounds 2 and 4 (each within the scatter of the next); then compounds 1 and 3 (each within the scatter of the next).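

In this assay, the change from methyl to ethyl gives a 3.6-fold lower number from compound 3 to compound 4 (0.56 log units; beyond the scatter), so this position does respond to growth of the group it carries. The earlier compounds shown here could not show this, since putting a methyl in place of hydrogen on the same aromatic carbon gave only a 1.2-fold higher number from compound 1 to compound 3 (0.06 log units; within the scatter), whereas ethyl in that place gives a 3.1-fold lower number from compound 1 to compound 4 (0.50 log units; beyond the scatter), a step beyond the scatter. No measurement shown here accounts for this difference between methyl and ethyl.

From the compounds shown here alone, whether the effect keeps growing with a longer chain such as propyl, or stops at ethyl, remains open. So does whether a branched group such as isopropyl, or an oxygen-bearing group such as methoxy, would behave like ethyl at this position.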